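This account rests on a few compounds, and the source may have more. Where it says the series, first, only, none or still open, it means among the compounds named here.

Working notes on the series. In a functional assay on RS4-11 cells (Homo sapiens) for inhibition, read by CCK-8 assay, with a stated time of 48 h, tested at 20 uM (on this read-out lower numbers stand for less inhibition of growth and higher numbers for more inhibition of growth at the one concentration tested), compound 1 `COc1ccc(S(=O)(=O)Oc2ccccc2/C=C(\C#N)C(=O)Nc2nnc(-c3cccs3)s2)cc1` gives 76%, compound 2 `COc1ccc(Cc2nnc(NC(=O)/C(C#N)=C/c3ccccc3OS(=O)(=O)c3ccc(OC)cc3)s2)cc1` gives 78% and compound 3 `COc1ccc(S(=O)(=O)Oc2ccccc2/C=C(\C#N)C(=O)Nc2nnc(Cc3cccc4ccccc34)s2)cc1` gives 78%. Compound 3 is therefore level with compound 2 and within the scatter of compound 1, so the three cannot be ranked.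

The next change leads to compound 4 `N#C/C(=C\c1ccccc1OS(=O)(=O)c1ccccc1[N+](=O)[O-])C(=O)Nc1nnc(Cc2cccc3ccccc23)s1`, with 2-nitrophenyl in place of 4-methoxyphenyl on a sulfonyl sulfur.

Three measured steps are available: a number 2 percentage points higher from compound 1 to compound 2 (within the scatter), a number 2 percentage points higher from compound 1 to compound 3 (within the scatter) and no change at the digits printed from compound 2 to compound 3 (within the scatter). All three alter the other substituent of the shared core and leave the group on the sulfonyl sulfur untouched, so the series holds no direct measure of this change. They bear on it only indirectly, and they show a flat read-out in this assay for that other substituent. No step beyond the scatter is expected, although the uncertainty is wide. The expected step is a number 5 percentage points lower from compound 3 to compound 4 (within the scatter). The estimate for compound 4 is 73%, with an expected range of 55% to 86%.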

Compound 4, percent growth inhibition at one concentration: 66%
Compound 4: the middle estimate sits 7 percentage points above what was measured; measured number inside the range.
By their numbers in this assay, from the lowest: compounds 4, 1, 2 and 3 (each within the scatter of the next, the first and the last beyond it).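

Within the data shown here, the group on the sulfonyl sulfur is the first place where the read-out moves beyond the scatter in this assay: 2-nitrophenyl in place of 4-methoxyphenyl gives a number 12 percentage points lower from compound 3 to compound 4 (beyond the scatter). The earlier steps, all at the other substituent of the shared core, stayed within the scatter, so this position responds where that substituent did not among the compounds shown. The step is modest and rests on a single pair, and nothing measured here accounts for it.

The change swaps two groups that differ in both substituent and its place on the ring, so a 4-nitrophenyl or an unsubstituted phenyl on the sulfonyl sulfur would be needed to separate the two. Going by these compounds, it also remains open whether the step holds with thiophen-2-yl or 4-methoxybenzyl as the other substituent.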